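The source may report more compounds than this note shows. Statements on the series, on what has been measured and on what is new or still open speak of the compounds shown alone.

Measured so far in a functional assay on COLO 205 cells (Homo sapiens) for inhibition, read by sulforhodamine B assay, with a stated time of 48 h; a lower number here means a stronger inhibitor of growth, a higher number a weaker inhibitor of growth:

Compound 1, `COc1cc(-c2nn(-c3cccc(NC(=O)c4ccc(Cl)c(C(F)(F)F)c4)c3)cc2-c2ccncc2)ccc1Cl`: 23300 nM
Compound 2, `O=C(Nc1cccc(-n2cc(-c3ccncc3)c(-c3ccc(Cl)c(O)c3)n2)c1)Nc1cc(C(F)(F)F)cc(C(F)(F)F)c1`: 1580 nM
Compound 3, `O=C(Nc1cccc(-n2cc(-c3ccncc3)c(-c3ccc(Cl)c(O)c3)n2)c1)Nc1cccc(C(F)(F)F)c1`: 23800 nM

Compound 1 stands second highest of the three numbers. Its nearest neighbour is compound 3, whose value sits within the scatter of compound 1; the furthest is compound 2, whose value lies well beyond the scatter on the lower side.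

Compound 4, `COc1cc(-c2nn(-c3cccc(NC(=O)Nc4ccc(Cl)c(Cl)c4)c3)cc2-c2ccncc2)ccc1Cl`, differs from compound 1 in one place: (3,4-dichlorophenyl)amino in place of 4-chloro-3-(trifluoromethyl)phenyl on a carbonyl carbon. The carbonyl thus becomes a urea carbonyl, and the aryl it carries changes from 4-chloro-3-(trifluoromethyl)phenyl to 3,4-dichlorophenyl.

For the measured compounds named here, no measured pair in this set covers the amide-to-urea change on the shared core of compound 1 directly. Going by the values given here, the one measured step, a 15-fold higher number from compound 2 to compound 3 (1.18 log units; beyond the scatter), lies among the ureas of a related core and shows that the substitution pattern on the terminal aryl of a urea can move this assay by a large margin. Compounds 2 and 3 also differ from compound 1 in the core, so they set only a loose frame: ureas on this scaffold have ranged from the value of compound 2 to the value of compound 3.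

For compound 4 a moderate lowering is expected, a 2.6-fold lower number from compound 1 to compound 4 (0.41 log units; beyond the scatter), with wide uncertainty. The estimate for compound 4 is 9000 nM, expected to fall between 2500 nM and 32000 nM.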

Compound 4, concentration for total growth inhibition: 1720 nM
Beside the measured number, compound 4's estimate is 5.2-fold (0.72 log units) above it, outside the stated range (below it).
By their numbers in this assay, from the lowest: compounds 2 and 4 (each within the scatter of the next); then compounds 1 and 3 (each within the scatter of the next).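

In this assay, putting (3,4-dichlorophenyl)amino in place of 4-chloro-3-(trifluoromethyl)phenyl on a carbonyl carbon gives a 14-fold lower number from compound 1 to compound 4 (1.13 log units; beyond the scatter) and shows that this position responds strongly on the shared core of compound 1. For the compounds shown here, the only earlier step, a 15-fold higher number from compound 2 to compound 3 (1.18 log units; beyond the scatter) in the same assay, came from a trifluoromethyl change on the terminal aryl of a urea on a different core, so the new step is the first large one at this carbonyl, where the neighbouring atom changes as well as the aryl substituents. The entering group brings a nitrogen with a hydrogen-bond donor and exchanges trifluoromethyl for chlorine, and no measurement available here accounts for the size of the step.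

Going by these compounds alone, the single step does not divide its size between the new amino nitrogen and the exchange on the aryl ring. A urea on the same core keeping 4-chloro-3-(trifluoromethyl)phenyl would separate these two parts, and a methylene or an oxygen in place of the amino nitrogen would test how far the gain depends on that nitrogen.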